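This account rests on a few compounds, and the source may have more. Where it says the series, first, only, none or still open, it means among the compounds named here.

Series so far, measured in an ADME assay on microsomes from liver (Mus musculus) for pharmacokinetics, read by LC-MS, using NADPH, with stated times of 5 min, 15 min and 30 min, tested at 10 uM; a higher number here means faster removal of the compound, a lower number slower removal:

- compound 1 `C[C@H](NC(=O)c1cccc(F)c1)c1ccc(NC(=O)N2CC(c3cccnc3)C2)cc1`: 60.9 mL.min-1.g-1
- compound 2 `C[C@@H](c1ccc(NC(=O)N2CC(c3cncc(N)c3)C2)cc1)N1Cc2ccccc2C1=O`: 158 mL.min-1.g-1

Compound 2 gives 158 mL.min-1.g-1, the higher of the two numbers in this assay and beyond the scatter from compound 1. The next compound to be read is compound 3 `C[C@H](NC(=O)c1cccc(F)c1)c1ccc(NC(=O)N2CC(c3cncc(N)c3)C2)cc1`, which keeps the rest of compound 2 and changes one group: a group of 10 heavy atoms (7 carbon, 1 nitrogen, 1 oxygen, 1 fluorine; one six-membered aromatic ring of carbon only) in place of a group of 10 heavy atoms (8 carbon, 1 nitrogen, 1 oxygen; one five-membered non-aromatic ring with 1 hetero atom, one six-membered aromatic ring of carbon only), on a saturated chain carbon bound to an aromatic carbon and a saturated chain carbon. The new ((3-fluorophenyl)carbonyl)amino group sits on a saturated chain carbon bound to an aromatic carbon and a saturated chain carbon.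

Going by the values given here, no two measured compounds differ in one place only, so the size of this step has no direct precedent. Among the compounds with values here, the only guide is compound 1, which carries the same ((3-fluorophenyl)carbonyl)amino group and gives 60.9 mL.min-1.g-1. Compound 1 also differs from compound 3 elsewhere in the structure, so the guide is a loose one. A modest fall in this assay is expected, probably within the scatter, with an estimated 1.7-fold lower number from compound 2 to compound 3 (0.22 log units; within the scatter). For compound 3 the expected value is 95 mL.min-1.g-1, with an estimated range of 45 mL.min-1.g-1 to 190 mL.min-1.g-1.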

Compound 3, intrinsic clearance in microsomes: 27.4 mL.min-1.g-1
Compound 3: middle estimate off by 3.5-fold (0.54 log units), on the high side; the whole stated range lies above it.
By their numbers in this assay, from the lowest: compound 3; then compound 1; then compound 2.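

In this assay, placing the ((3-fluorophenyl)carbonyl)amino group on the saturated chain carbon, in place of the group with the five-membered non-aromatic ring, gives a 5.8-fold lower number from compound 2 to compound 3 (0.76 log units; beyond the scatter), so the number in this assay responds clearly to the group at this place. With that group held constant, amino in place of hydrogen on an aromatic carbon gives a 2.2-fold lower number from compound 1 to compound 3 (0.35 log units; beyond the scatter), so a second place in the series also moves the number beyond the scatter, and compound 3 stands lowest in both comparisons. No measurement here bears on why either change is followed by a lower number.

As far as these compounds go, it remains open whether the step at the saturated chain carbon depends on the fluorine, which an unsubstituted phenylcarbonylamino group or a 3-chlorophenylcarbonylamino group would help to settle. From the compounds shown here alone, it also remains open how far the step at the aromatic carbon is specific to amino, as a methylamino group, a hydroxyl group or a methoxy group at that carbon could show, and whether it carries over when the group with the five-membered non-aromatic ring is present.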